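This account rests on a few compounds, and the source may have more. Where it says the series, first, only, none or still open, it means among the compounds named here.

The measured compounds in this assay:

Compound 1, `CC(=O)OC/C(=C\c1ccccc1Br)C(=O)c1ccccc1`, gives 22000 nM in a functional assay on HBL-100 cells (Homo sapiens) for inhibition, read by sulforhodamine B assay, with a stated time of 48 h; a lower number here means a stronger inhibitor of growth, a higher number a weaker inhibitor of growth.
Compound 2, `CC(=O)OC/C(=C\c1ccccc1F)C(=O)c1ccccc1`, gives 17000 nM.
Compound 3, `CC(=O)OC/C(=C\c1ccccc1[N+](=O)[O-])C(=O)c1ccccc1`, gives 26000 nM.

Compound 3 stands at the highest of the three numbers, but its distance to the other two is small: a 1.2-fold higher number from compound 1 to compound 3 (0.07 log units; within the scatter), and a 1.5-fold higher number from compound 2 to compound 3 (0.18 log units; within the scatter). The remaining pair behaves the same way, a 1.3-fold lower number from compound 1 to compound 2 (0.11 log units; within the scatter). All three measured compounds share one core and differ only in the group on the aromatic ring, and none of those changes moved the number beyond the scatter.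

Compound 4, `O=C(OC/C(=C\c1ccccc1[N+](=O)[O-])C(=O)c1ccccc1)c1ccccc1`, is the next compound. Its change from compound 3 is phenyl in place of methyl on a carbonyl carbon; cut one bond further out, this reads acetyl to benzoyl, or acetoxy to benzoyloxy. Among the compounds with values here, no measured step touches this part of the molecule; every step so far sits on the aromatic ring, so nothing among the three values speaks directly to the ester. What the data do show is that the core has given numbers of one size across three substituents. Within the data shown here, on that basis the step is expected to be a 1.3-fold lower number from compound 3 to compound 4 (0.11 log units; within the scatter), with a wide range because no measured step supports it. The estimate for compound 4 in this assay is 20000 nM, expected to lie between 6000 nM and 60000 nM.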

Compound 4, concentration for 50% growth inhibition: 3900 nM
Estimate against measurement, compound 4: 5.1-fold (0.71 log units) above; the whole stated range lies above it.
By their numbers in this assay, from the lowest: compound 4; then compounds 2, 1 and 3 (each within the scatter of the next).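

Within the data shown here, the ester end of the molecule is the first place where a single change moves the number beyond the scatter: in this assay, phenyl in place of methyl on a carbonyl carbon gives a 6.7-fold lower number from compound 3 to compound 4 (0.82 log units; beyond the scatter), whereas the bromo, fluoro and nitro compounds all stayed within the scatter of one another. Among these compounds, this position, which no earlier step touched, therefore responds to the change from acetoxy to benzoyloxy in a way that the ring substituents did not, and the change adds one six-membered aromatic ring of carbon only, with no hydrogen-bond donor or acceptor entering or leaving. Nothing available here explains the size of this step.

The change from acetoxy to benzoyloxy is shown only with the nitro group on the aromatic ring, so whether it would give a similar step with bromo or fluoro there remains open. From the compounds shown here alone, it is also open whether the step needs an aromatic ring at all, or whether a longer chain, such as butyryl, or an amine carried on the phenyl would give a number nearer that of compound 4 or compound 3.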